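The source may report more compounds than this note shows. Statements on the series, on what has been measured and on what is new or still open speak of the compounds shown alone.

Measured so far in a physicochemical assay for lipophilicity, in phosphate buffer, measured as octanol-water partition, with a stated time of 3 min, at pH 7.4; on this read-out lower numbers stand for lower lipophilicity and higher numbers for higher lipophilicity:
compound 1 `CNc1ccc(-c2nc3cc(OCCOCCOCCF)ccc3o2)cn1` gives 2.86
compound 2 `CNc1ccc(-c2nc3cc(OCCF)ccc3o2)cn1` gives 3.52
compound 3 `CNc1ccc(-c2nc3ccc(OCCOCCOCCF)cc3s2)cn1` gives 2.85

Compound 2 differs from compound 1 by fluoro in place of 2-(2-fluoroethoxy)ethoxy on a saturated chain carbon, two bonds along the chain from an oxygen on an aromatic ring; that change gave a step of a number 0.66 log units higher from compound 1 to compound 2 (beyond the scatter). Compound 3 carries a core unlike that of compound 1; the difference between the two cores is not broken down here. The values of compound 3 and compound 1 in this assay lie within the scatter of each other.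

Compound 4 `CNc1ccc(-c2nc3ccc(OCCF)cc3s2)cn1` is not yet measured. It differs from compound 3 by fluoro in place of 2-(2-fluoroethoxy)ethoxy on a saturated chain carbon, two bonds along the chain from an oxygen on an aromatic ring, the same change as from compound 1 to compound 2, at the same place. Only that one earlier occurrence is available to rest on. The expected step is a number 0.66 log units higher from compound 3 to compound 4 (beyond the scatter), because the same change gave a number 0.66 log units higher from compound 1 to compound 2 (beyond the scatter). In this assay compound 4 is estimated at 3.51, with a range from 3.2 to 3.8.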

Compound 4, distribution coefficient: 3.59
For compound 4 the middle estimate is 0.08 log units below the measured one, and the stated range covers the measured number.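

In this assay, putting fluoro in place of 2-(2-fluoroethoxy)ethoxy gives a number 0.74 log units higher from compound 3 to compound 4 (beyond the scatter) on one core and a number 0.66 log units higher from compound 1 to compound 2 (beyond the scatter) on the other, so the change carries over between these two cores in the same direction, with both steps beyond the scatter. This rests on one pair per core and does not show that the change would carry over to any further core or to another place on the molecule. Nothing available here explains the step.

Open, from the compounds shown here alone, is how a longer chain would read in this assay on either core. Also open, going by these compounds, is what an amine or a carboxylic acid in place of fluoro would give.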